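Adding a Third Fluorine: Cytotoxicity Expected to Stay Beyond Reach

This account rests on a few compounds, and the source may have more. Where it says the series, first, only, none or still open, it means among the compounds named here.

Three analogues share one core and differ only in the fluorine pattern on the benzyl group. In an ADME assay on Vero cells (Chlorocebus sabaeus) for cytotoxicity, with a stated time of 72 h (a higher number here means a weaker inhibitor, a lower number a stronger inhibitor), compound 1 `CCOC(=O)c1cc(-c2cccc(OCc3cccc(F)c3F)c2)on1` gives only a limit, > 128000 nM. Compound 2 `CCOC(=O)c1cc(-c2cccc(OCc3c(F)cccc3F)c2)on1` likewise reaches only a limit in this assay, > 128000 nM. Compound 3 `CCOC(=O)c1cc(-c2cccc(OCc3ccc(F)cc3F)c2)on1` also stands at a limit in this assay, > 128000 nM. Because of the limit of > 128000 nM in this assay, at which 3 of the 3 values shown sit, the steps a step that the two limits leave unreadable from compound 1 to compound 2, a step that the two limits leave unreadable from compound 1 to compound 3 and a step that the two limits leave unreadable from compound 2 to compound 3 have no readable size. Compound 4 `CCOC(=O)c1cc(-c2cccc(OCc3ccc(F)c(F)c3F)c2)on1` differs from compound 3 by fluoro in place of hydrogen on an aromatic carbon. Among the compounds with values here, since none of the measured steps can be read, no step beyond the scatter is expected in this assay, a step that the limit leaves unreadable from compound 3 to compound 4. Compound 4 is therefore estimated in this assay at 160000 nM, between 64000 nM and 500000 nM, and most likely reported again only as a limit.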

Compound 4, half-maximal inhibitory concentration: > 128000 nM
Compound 4: a limit, no number (the forecaster's own chance of this, stated with the estimate: 85%); the middle value does not contradict the limit.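

Compound 4 also gives only a limit in this assay, so no step among compound 1, compound 2, compound 3 and compound 4 can be read: the limit of > 128000 nM in this assay, at which 4 of the 4 values shown sit.

The compounds shown leave open at what concentration any of them would register in this assay, and whether the fluorine pattern matters there at all.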